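A Methyl Removed: From Compound 1 to Compound 3

The compounds below may be only part of what the source reports. "The series", "measured", "known", "first", "only" and "open" are said of these compounds alone.

Compound 1 `CC1=CS(=O)(=O)c2cc(NC(=O)c3cc([N+](=O)[O-])c(Sc4c(Cl)cncc4Cl)s3)ccc21` and compound 2 `CN(C)CCCNC1CS(=O)(=O)c2cc(NC(=O)c3cc([N+](=O)[O-])c(Sc4c(Cl)cncc4Cl)s3)ccc21` share a core and differ only in what hangs from the five-membered ring bearing the sulfur. In an assay on isolated protein for inhibition of ubiquitin carboxyl-terminal hydrolase 7 (Homo sapiens) (a higher number here means a weaker inhibitor, a lower number a stronger inhibitor), compound 1 gives 170 nM. Compound 2 gives 200 nM in this assay, so compound 1 stands at the lower of the two numbers, yet its gap to compound 2 lies within the usual scatter and no order between them can be read from it.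

Compound 3 `O=C(Nc1ccc2c(c1)S(=O)(=O)C=C2)c1cc([N+](=O)[O-])c(Sc2c(Cl)cncc2Cl)s1` has not yet been measured. It differs from compound 1 by one change: hydrogen in place of methyl on a double-bonded ring carbon. No measured pair of this kind exists among these compounds, so the size of the step can only be estimated; the loss of a methyl is expected to leave the number close to that of compound 1, with a step of a 1.5-fold higher number from compound 1 to compound 3 (0.17 log units; within the scatter) expected to be small and not clearly beyond the scatter in either direction. Compound 3 is therefore expected to give about 250 nM in this assay, within a range from 100 nM to 650 nM.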

Compound 3, half-maximal inhibitory concentration: 100 nM
Compound 3: the middle estimate sits 2.5-fold (0.40 log units) above what was measured, and the stated range covers the measured number.
By their numbers in this assay, from the lowest: compounds 3, 1 and 2 (each within the scatter of the next).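

For the compounds shown here, the step of a 1.7-fold lower number from compound 1 to compound 3 (0.23 log units; within the scatter) gives the first direct reading of this position in this assay, and it lies within the scatter. On a double-bonded ring carbon, two ring bonds from the ring sulfur, the methyl can therefore give way to hydrogen without a change that can be told from the scatter, and compound 3 gives 100 nM with no group there at all. No independent measurement bears on this result.

Still open, from the compounds shown here alone, is whether a group larger than methyl, such as an ethyl, a longer chain or a carboxylic acid, would be tolerated on that same double-bonded ring carbon. Compound 2 differs from compound 3 in more than one place, so its amine chain gives no reading of this question.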